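Side-chain amine change in the series: working notes

This account rests on a few compounds, and the source may have more. Where it says the series, first, only, none or still open, it means among the compounds named here.

Compound 1 `CCOC(=O)c1c(CN2CCCC2)nc2ccc(Cl)cc2c1-c1ccccc1` gives 490000 nM in this series
Compound 2 `O=C(O)c1c(CNCc2ccccc2Cl)nc2ccc(Cl)cc2c1-c1ccccc1` gives "not determined" (no result reported) in this series

Among the measured compounds shown here, in an ADME assay on COS-7 cells (Chlorocebus aethiops) for cytotoxicity, read by MTT assay, with a stated time of 24 h (on this read-out higher numbers stand for lower toxicity in this test and lower numbers for higher toxicity in this test), compound 1 at 490000 nM holds the only number, so its standing cannot be ranked against any other compound. For the measured compounds named here, compound 2 offers no result for comparison, and no measured step exists to size a structural change.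

Compound 3 `CCOC(=O)c1c(CN(C)Cc2ccccc2)nc2ccc(Cl)cc2c1-c1ccccc1` keeps the core of compound 1, and the change is benzyl(methyl)amino in place of pyrrolidin-1-yl on a saturated chain carbon bound to an aromatic carbon with everything else the same. The data give no direct guide to this change, so the expectation is a cautious one. The expected step, a 2.5-fold lower number from compound 1 to compound 3 (0.39 log units; beyond the scatter), is modest and points towards lower numbers in this assay, though it may prove no larger than the usual scatter. For compound 3 the estimated value is 200000 nM, with an expected range from 60000 nM to 600000 nM in this test.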

Compound 3, half-maximal cytotoxic concentration: 315000 nM
For compound 3 the middle estimate is 1.6-fold (0.20 log units) below the measured one; the measured number falls inside the stated range.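

In this assay, the place on a saturated chain carbon bound to an aromatic carbon now has its first measured step: benzyl(methyl)amino in place of pyrrolidin-1-yl gives a 1.6-fold lower number from compound 1 to compound 3 (0.19 log units; within the scatter) on the core of compound 1. Going from 5 to 9 heavy atoms, and from a five-membered non-aromatic ring to a six-membered aromatic ring of carbon only, therefore does not separate the two compounds on this read-out, although this rests on a single pair. No supporting data bear on why the change has this outcome.

Whether this holds for other amines is open, for example morpholin-4-yl or a simple dimethylamino group at the same place. As far as these compounds go, it is also open whether a longer chain between the amine and the shared core would give the same picture.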